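Phenyl to Methyl on the Shared Core of Compound 2

The source may report more compounds than this note shows. Statements on the series, on what has been measured and on what is new or still open speak of the compounds shown alone.

Compound 1 `CN(C)c1nc(N)sc1C(=O)c1cnc2ccccn12` gives 32% in a functional assay on the whole organism (strain Sprague-Dawley) for inhibition, with Rattus norvegicus as the target, read by paw edema, with stated times of 1 h and 3 h, at a dose of 50 mg/kg by the oral route; a lower number here means less inhibition, a higher number more inhibition at the dose given (going by the name of the read-out).
Compound 2 `Nc1nc(-c2ccccc2)c(C(=O)c2cnc3ccccn23)s1` gives 40% in this assay.
Compound 3 `Cc1cccn2c(C(=O)c3sc(N)nc3-c3ccccc3)cnc12` gives 20% in this assay.

Within the data shown here, compound 2 shows the highest number of the three, but the step of a number 8 percentage points higher from compound 1 to compound 2 (within the scatter) lies within the scatter, so compound 1 and compound 2 cannot be told apart; only the step of a number 20 percentage points lower from compound 2 to compound 3 (beyond the scatter) is beyond it, and that change sits on the other ring.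

Compound 4 `Cc1nc(N)sc1C(=O)c1cnc2ccccn12` differs from compound 2 by methyl in place of phenyl on an aromatic carbon. Among the measured compounds shown here, the one step at this place, a number 8 percentage points higher from compound 1 to compound 2 (within the scatter), was within the scatter, so a small group or a large one here made little difference. Compound 4 is therefore expected to give roughly a number 7 percentage points lower from compound 2 to compound 4 (within the scatter), no step beyond the scatter. The estimate for compound 4 is 33%, expected between 15% and 50%.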

Compound 4, a percentage reported as inhibition, in the whole organism at one dose (the size of the read-out at that dose, not a potency): 53%
Compound 4: the middle estimate sits 20 percentage points below what was measured, outside the stated range (above it).
By their numbers in this assay, from the lowest: compound 3; then compounds 1 and 2 (each within the scatter of the next); then compound 4.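

Among these compounds, this position is less indifferent than the earlier compounds suggested: in this assay, methyl in place of phenyl gives a number 13 percentage points higher from compound 2 to compound 4 (beyond the scatter), and methyl in place of dimethylamino gives a number 21 percentage points higher from compound 1 to compound 4 (beyond the scatter). Phenyl and dimethylamino could not be told apart, yet methyl, with its single carbon and no ring, stands beyond the scatter of both. Nothing available here explains this rise. As far as these compounds go, whether an ethyl group or a longer chain at this position would keep the higher number remains open. Also open, from the compounds shown here alone, is whether the methyl on the other ring, as in compound 3, would lower the number on compound 4 too.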